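Methoxy on the saturated ring carbon of the shared core

This account rests on a few compounds, and the source may have more. Where it says the series, first, only, none or still open, it means among the compounds named here.

Measured compounds:
- compound 1 `CC(C)N(C(=O)CN1C=CN(c2ccccc2)C(=O)C(Cc2n[nH]c3ccccc23)C1=O)c1ccc(F)cc1` — 50.1 nM
- compound 2 `COc1ccc(N(C(=O)CN2C=CN(c3ccccc3)C(=O)C(Cc3n[nH]c4ccccc34)C2=O)C(C)C)cc1` — 29.5 nM
- compound 3 `CC(C)N(C(=O)CN1C=CN(c2ccccc2)C(=O)C(Cc2n[nH]c3ccccc23)C1=O)c1ccc(O)cc1` — 550 nM; 158 nM; 52.5 nM (3 entries)

In a functional assay on CHO cells for agonist activity at Melanocyte-stimulating hormone receptor (Homo sapiens), read by a luciferase reporter, with a stated time of 4 h (on this read-out higher numbers stand for an effect only at larger amounts of compound and lower numbers for an effect already at smaller amounts), compound 2 gives 29.5 nM, the lowest of the two single numbers in the series. Its nearest neighbour is compound 1, and the step of a 1.7-fold lower number from compound 1 to compound 2 (0.23 log units; within the scatter) lies within the scatter, so the two are not distinguished. Compound 3 has no single number: its several entries the several entries of compound 3 in this assay, 550 nM; 158 nM; 52.5 nM (3 entries) spread widely, and they are read as a sign of variability in this assay rather than as a fixed value.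

Compound 4 `COc1ccc(N(C(=O)CN2C=CN(c3ccccc3)C(=O)C(Cc3n[nH]c4ccccc34)(OC)C2=O)C(C)C)cc1` is the next compound to be measured in this assay. It differs from compound 2 in one place: methoxy in place of hydrogen on a saturated ring carbon. Among the compounds with values here, none of the measured steps touches this position. Within the data shown here, the only measured step, a 1.7-fold lower number from compound 1 to compound 2 (0.23 log units; within the scatter), concerns a substituent on an aromatic carbon and was within the scatter, so it gives no guidance on a change at the saturated ring carbon that carries the large group. Among the measured compounds shown here, no precedent for substitution at this carbon exists.

The expectation therefore rests on the absence of data rather than on a trend. Compound 4 is expected to give 80 nM, with a range from 20 nM to 400 nM. The step of a 2.7-fold higher number from compound 2 to compound 4 (0.43 log units; beyond the scatter) is the estimated change from compound 2, set wide because nothing measured here constrains it.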

Compound 4, half-maximal effective concentration: 1380 nM
For compound 4 the middle estimate is 17-fold (1.24 log units) below the measured one; the measured number lies above the stated range.
By their numbers in this assay, from the lowest: compounds 2 and 1 (each within the scatter of the next); then compound 4.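

In this assay, the saturated ring carbon of the seven-membered non-aromatic ring proves sensitive to substitution: methoxy in place of hydrogen brings a 47-fold higher number from compound 2 to compound 4 (1.67 log units; beyond the scatter). The change on the aromatic carbon, by contrast, gave a 1.7-fold lower number from compound 1 to compound 2 (0.23 log units; within the scatter), so among the pairs shown, the number responds far more to the change at the saturated ring carbon than to the one on the aromatic carbon. This shift also stands out against the widest variation seen between repeated entries in the series, so it is unlikely to be an artefact of assay variability, although compound 4 has only one entry: the several entries of compound 3 in this assay, 550 nM; 158 nM; 52.5 nM (3 entries).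

A single replacement at this carbon cannot separate an effect specific to methoxy from one shared by any group there, and a methyl group, an amine or a longer chain such as ethoxy at the same carbon would show whether the loss follows the kind of group or occurs with any replacement of the hydrogen. Also open is whether the same step would appear with the fluoro substituent of compound 1 on the aromatic ring, and the compounds shown give no reason for the size of the step.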